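This account rests on a few compounds, and the source may have more. Where it says the series, first, only, none or still open, it means among the compounds named here.

Measured so far: compound 1 `O=C1[C@H]2[C@H](ON(c3ccccc3)[C@@H]2c2coc3ccc(F)cc3c2=O)C(=O)N1c1ccccc1`, > 60000 nM; compound 2 `Cc1ccc2occ([C@@H]3[C@H]4C(=O)N(c5ccccc5)C(=O)[C@H]4ON3c3ccccc3)c(=O)c2c1`, 11100 nM.

In a functional assay on PC-3 cells (Homo sapiens) for inhibition, read by sulforhodamine B assay, with a stated time of 48 h (on this read-out higher numbers stand for weaker inhibition and lower numbers for stronger inhibition), compound 1 gives only a limit, > 60000 nM. For the measured compounds named here, compound 2 gives 11100 nM, the only number among the two values shown. The step of an at least 5.4-fold lower number from compound 1 to compound 2 (0.73 log units; beyond the scatter) lies beyond the scatter. Compound 3 `O=C1[C@H]2[C@H](ON(c3ccccc3)[C@@H]2c2coc3ccc(Br)cc3c2=O)C(=O)N1c1ccccc1` differs from compound 2 by bromo in place of methyl on an aromatic carbon. Going by the values given here, only that single measured step bears on this new change, and it concerns a different exchange. A step of about a 1.4-fold higher number from compound 2 to compound 3 (0.13 log units; within the scatter) in this assay is expected for compound 3, with a limit remaining possible. Compound 3 is therefore estimated at 15000 nM, between 5000 nM and 60000 nM.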

Compound 3, half-maximal inhibitory concentration: 13300 nM
Compound 3: middle estimate off by 1.1-fold (0.05 log units), on the high side; the measured number falls inside the stated range.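

In this assay, methyl and bromo at this position cannot be told apart, with a 1.2-fold higher number from compound 2 to compound 3 (0.08 log units; within the scatter). Bromo in place of fluoro gives an at least 4.5-fold lower number from compound 1 to compound 3 (0.65 log units; beyond the scatter), so two different groups now stand apart from fluoro beyond the scatter, which the single earlier step could not show. Compound 1 remains a limit and not a number: the limit of > 60000 nM in this assay, at which 1 of the 3 values shown sits.

The compounds shown leave open how far fluoro stands apart from the other two groups. They also leave open whether an amine, a methoxy group or a carboxylic acid on this carbon would fit with methyl and bromo or with fluoro.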